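Swapping the ether tail for an ester on the shared core

The compounds below may be only part of what the source reports. "The series", "measured", "known", "first", "only" and "open" are said of these compounds alone.

Measured compounds and their values in a functional assay on MCF7 cells (Homo sapiens) for antiproliferative activity, read by MTT assay, with a stated time of 48 h; on this read-out lower numbers stand for stronger inhibition and higher numbers for weaker inhibition:
- compound 1 `COc1ncc(-c2ccc3nc(NC(=O)C4CC4)nn3c2)cc1NS(=O)(=O)c1ccc(F)cc1`: 2590 nM
- compound 2 `COc1ncc(-c2ccc3nc(N)nn3c2)cc1NS(=O)(=O)c1ccc(F)cc1`: 1930 nM
- compound 3 `CCOCCNc1nc2ccc(-c3cnc(OC)c(NS(=O)(=O)c4ccc(F)cc4)c3)cn2n1`: 1350 nM

All three compounds share one core and differ only in what sits on a nitrogen of an aromatic ring. Compound 3 gives the lowest of the three numbers, yet it is separated from compound 2 by only a 1.4-fold lower number from compound 2 to compound 3 (0.16 log units; within the scatter) and from compound 1 by a 1.9-fold lower number from compound 1 to compound 3 (0.28 log units; within the scatter), so the three measured numbers cannot be told apart.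

Compound 4 `CCOC(=O)CNc1nc2ccc(-c3cnc(OC)c(NS(=O)(=O)c4ccc(F)cc4)c3)cn2n1` is the next variation. Relative to compound 3 the change is ethoxycarbonyl in place of ethoxymethyl on a saturated chain carbon bound to a nitrogen on an aromatic ring. The measured steps that bear on it are those that reshape the same side group: from a carbonyl-bearing group to hydrogen a 1.3-fold lower number from compound 1 to compound 2 (0.13 log units; within the scatter), from that carbonyl-bearing group to the ether chain a 1.9-fold lower number from compound 1 to compound 3 (0.28 log units; within the scatter), and from hydrogen to the ether chain a 1.4-fold lower number from compound 2 to compound 3 (0.16 log units; within the scatter). Each of these was within the scatter. Nothing in the data therefore points to a step beyond the scatter in this assay, in either direction, when the ether carbon is turned into a carbonyl.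

Compound 4 is expected to give about 1500 nM, most likely between 700 nM and 3200 nM. The expected step is a 1.1-fold higher number from compound 3 to compound 4 (0.05 log units; within the scatter).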

Compound 4, half-maximal inhibitory concentration: 4410 nM
The estimate for compound 4 lay 2.9-fold (0.47 log units) below the measured number; measured number outside the range, above it.
By their numbers in this assay, from the lowest: compounds 3, 2, 1 and 4 (each within the scatter of the next, the first and the last beyond it).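

Until now, every change on this nitrogen stayed within the scatter, but exchanging ethoxymethyl for ethoxycarbonyl on the saturated chain carbon moves the number beyond it in this assay (a 3.3-fold higher number from compound 3 to compound 4 (0.51 log units; beyond the scatter)). Compound 4 also separates from the compound with only hydrogen on that nitrogen (a 2.3-fold higher number from compound 2 to compound 4 (0.36 log units; beyond the scatter)), although the step is modest, while its difference from the compound with the cyclopropylcarbonyl group stays within the scatter (a 1.7-fold higher number from compound 1 to compound 4 (0.23 log units; within the scatter)). The position is therefore not indifferent to what its chain carries: 2-ethoxyethyl and (ethoxycarbonyl)methyl are closely related side groups, yet the step between them is the largest among these four compounds.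

No measurement available here explains why the carbonyl in the chain goes with the higher number.

The compounds shown leave open whether the step follows the ester itself or would also appear with a carboxylic acid, an amide or a ketone in the same chain. They also leave open how a longer chain between the nitrogen and the ester, or an amine at the end of the chain, would read in this assay.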